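The source may hold more compounds than are shown below. What is called first, only, known or untested is meant among the compounds shown, and "the series" means these compounds.

Compound 1 `COc1cc(NC(=O)Nc2cccc3c(Nc4cc(OC)cc(OC)c4)ncnc23)cc(OC)c1`: 366 nM
Compound 2 `COc1cc(Nc2ncnc3c(NC(=O)Nc4ccc(C)c(C)c4)cccc23)cc(OC)c1`: 8.8 nM
Compound 3 `COc1cc(Nc2ncnc3c(NC(=O)Nc4ccccc4Cl)cccc23)cc(OC)c1`: 356 nM

All three values come from a functional assay on RT-112 cells (Homo sapiens) for antiproliferative activity, read by MTT assay, with a stated time of 72 h; a higher number here means a weaker inhibitor of growth, a lower number a stronger inhibitor of growth. Compound 3 stands at the high end of this short series: a 1.0-fold lower number from compound 1 to compound 3 (0.01 log units; within the scatter), whereas a 40-fold higher number from compound 2 to compound 3 (1.61 log units; beyond the scatter).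

Next is compound 4 `COc1cc(Nc2ncnc3c(NC(=O)Nc4cc(Cl)cc(Cl)c4)cccc23)cc(OC)c1`, with 3,5-dichlorophenyl in place of 2-chlorophenyl on an amide-type nitrogen.

Within the data shown here, all the measured steps fall at this same place, and they show that the outcome there varies widely. There is a 42-fold lower number from compound 1 to compound 2 (1.62 log units; beyond the scatter), but also a 1.0-fold lower number from compound 1 to compound 3 (0.01 log units; within the scatter). Among the measured compounds shown here, no measured pair isolates the added chlorine. The nearest guide is compound 1, which also carries a 3,5-disubstituted phenyl and gives 366 nM. Compound 2 at 8.8 nM leaves room for a much lower number. A moderate move to a lower number is therefore expected, though no change beyond the scatter remains possible. The expected step is a 3.0-fold lower number from compound 3 to compound 4 (0.47 log units; beyond the scatter). Compound 4 is estimated at 120 nM, with an expected range of 20 nM to 500 nM.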

Compound 4, concentration for 50% growth inhibition: 30.2 nM
Compound 4: middle estimate off by 4.0-fold (0.60 log units), on the high side, and the stated range covers the measured number.
By their numbers in this assay, from the lowest: compound 2; then compound 4; then compounds 3 and 1 (each within the scatter of the next).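

In this assay, the 3,5-dichlorophenyl group on the amide-type nitrogen separates compound 4 from the earlier weaker pair (a 12-fold lower number from compound 3 to compound 4 (1.07 log units; beyond the scatter); a 12-fold lower number from compound 1 to compound 4 (1.08 log units; beyond the scatter)), so the tie between 2-chlorophenyl and 3,5-dimethoxyphenyl does not extend to every phenyl at this position. The two 3,5-disubstituted phenyl groups differ widely, showing that the substituent matters here and not only its placement on the ring, while compound 2 keeps the lowest number (a 3.4-fold higher number from compound 2 to compound 4 (0.54 log units; beyond the scatter)). No measured property is available to explain these differences.

The compounds shown leave open how 3-chlorophenyl and 3,5-dimethylphenyl would compare, which would help separate the effect of the substituent from that of its placement. As far as these compounds go, it also remains open whether a phenyl bearing an amine or a carboxylic acid would fit the same trend.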